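This account rests on a few compounds, and the source may have more. Where it says the series, first, only, none or still open, it means among the compounds named here.

Series notes, aryl replacement at the para position of the shared core.

In a functional assay on HEK293 cells for agonist activity at Bombesin receptor subtype-3 (Mus musculus), read by luminescence and calcium flux, with a stated time of 10 min (on this read-out lower numbers stand for an effect already at smaller amounts and higher numbers for an effect only at larger amounts of compound), compound 1 `CCC(C)(C)Cc1c[nH]c(CCc2ccc(-c3cccc(C#N)n3)cc2)n1` gives 115 nM. Among the three compounds measured so far it holds the second highest number, but the spread is small: compound 3, nearest to it, differs by a 1.0-fold higher number from compound 1 to compound 3 (0.01 log units; within the scatter), and compound 2, furthest from it, by a 1.1-fold lower number from compound 1 to compound 2 (0.02 log units; within the scatter).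

Compound 2 `CCC(C)(C)Cc1c[nH]c(CCc2ccc(-c3csnn3)cc2)n1` gives 109 nM in this assay; compound 3 `CCC(C)(C)Cc1c[nH]c(CCc2ccc(-c3cnsc3)cc2)n1` gives 119 nM. The step between these two five-membered heteroaryl analogues is a 1.1-fold higher number from compound 2 to compound 3 (0.04 log units; within the scatter).

Compound 4 `CCC(C)(C)Cc1c[nH]c(CCc2ccc(-c3ccns3)cc2)n1` is not yet measured. It differs from compound 1 as follows: 1,2-thiazol-5-yl in place of 6-cyanopyridin-2-yl on an aromatic carbon. Among the measured compounds shown here, the steps that bear on this are the two earlier exchanges of the 6-cyanopyridin-2-yl group for a five-membered ring with two hetero atoms, namely a 1.1-fold lower number from compound 1 to compound 2 (0.02 log units; within the scatter) and a 1.0-fold higher number from compound 1 to compound 3 (0.01 log units; within the scatter), both within the scatter. The exchange for 1,2-thiazol-5-yl is of the same kind, so no step beyond the scatter is expected in this assay in either direction.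

Compound 4 is therefore expected to give about 115 nM in this assay, within a range of 55 nM to 240 nM, corresponding to an expected step of no change at the digits printed from compound 1 to compound 4 (within the scatter).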

Compound 4, half-maximal effective concentration: 103 nM
Compound 4: the middle estimate sits 1.1-fold (0.05 log units) above what was measured; the range from low to high includes it.
By their numbers in this assay, from the lowest: compounds 4, 2, 1 and 3 (each within the scatter of the next).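

Working notes on the series: the new pair of isomers shows that the ring's point of attachment at this place makes no step beyond the scatter in this assay, with 1,2-thiazol-5-yl in place of 1,2-thiazol-4-yl giving a 1.2-fold lower number from compound 3 to compound 4 (0.06 log units; within the scatter) within the series. The earlier compounds shown here held no such pair, in which the same ring is joined through a different ring atom. Against the other two groups the picture is equally flat, with a 1.1-fold lower number from compound 1 to compound 4 (0.05 log units; within the scatter) for the exchange of 6-cyanopyridin-2-yl and its nitrile and a 1.1-fold lower number from compound 2 to compound 4 (0.02 log units; within the scatter) for the exchange of 1,2,3-thiadiazol-4-yl, so the four aromatic groups on this aromatic carbon, para to a large group, cannot be told apart here, and no measurement at hand offers an explanation for this.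

What an amine, a carboxylic acid or a longer alkyl chain would give at this place stays open, since only aromatic rings are shown there. Also open, going by these compounds, is whether this flat picture would hold with another group elsewhere on the shared core.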